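Will a Methyl on a Different Carbon Cost the Same?

The source may hold more compounds than are shown below. What is called first, only, known or untested is meant among the compounds shown, and "the series" means these compounds.

Three compounds have been measured so far:
Compound 1, `Cn1nc(-c2ccnc(Nc3ccc([N+](=O)[O-])cc3)n2)c2ccccc21`, gives in a functional assay on MCF7 cells (Homo sapiens) for antiproliferative activity, read by MTT assay, with a stated time of 72 h (a higher number here means a weaker inhibitor of growth, a lower number a stronger inhibitor of growth), a value of 11800 nM.
Compound 2, `CCn1nc(-c2ccnc(Nc3ccc([N+](=O)[O-])cc3)n2)c2ccccc21`, gives in this assay a value of 24000 nM.
Compound 3, `Cc1nn(-c2ccnc(Nc3cccc(S(N)(=O)=O)c3)n2)c2ncccc12`, gives in this assay a value of 20000 nM.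

Compound 4, `CCc1nn(-c2ccnc(Nc3cccc(S(N)(=O)=O)c3)n2)c2ncccc12`, awaits measurement. Compound 1 and compound 2 differ by methyl in place of hydrogen on a saturated chain carbon bound to an aromatic nitrogen, a change that produced a 2.0-fold higher number from compound 1 to compound 2 (0.31 log units; beyond the scatter). Compound 3 and compound 4 differ by methyl in place of hydrogen on a saturated chain carbon bound to an aromatic carbon. The two changes are the same kind of change but not the same: in the first the saturated chain carbon is bound to an aromatic nitrogen, in the second to an aromatic carbon. The difference between the core of compound 1 and the core of compound 3 is not broken down here, so the cores must be treated as separate. Because a 2.0-fold higher number from compound 1 to compound 2 (0.31 log units; beyond the scatter) was modest, a step of similar size is expected for compound 4, namely a 1.8-fold higher number from compound 3 to compound 4 (0.26 log units; within the scatter). Compound 4 is thus estimated at 36000 nM, with a likely range from 15000 nM to 90000 nM.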

Compound 4, concentration for 50% growth inhibition: 73200 nM
Compound 4: the middle estimate sits 2.0-fold (0.31 log units) below what was measured, and the stated range covers the measured number.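

Adding the methyl again gave a weaker inhibitor of growth, with a 3.7-fold higher number from compound 3 to compound 4 (0.56 log units; beyond the scatter). Both steps run in the same direction, and in this assay their sizes cannot be told apart, so the change carried over from one core to the other in these two pairs: the same change on two cores in this assay, a 2.0-fold higher number (0.31 log units; beyond the scatter) from compound 1 to compound 2 and a 3.7-fold higher number (0.56 log units; beyond the scatter) from compound 3 to compound 4, 1.8-fold (0.26 log units) apart, within the scatter of two such steps. This rests on just two pairs, so it does not show that a step of this size would hold on any further core, nor does it explain why the added methyl weakens growth inhibition.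

The chains shown end at ethyl, so it remains open whether a longer chain such as propyl would continue the trend on either core. From the compounds shown here alone, it also remains open how an amine or a carboxylic acid at the end of that chain would compare.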